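This account rests on a few compounds, and the source may have more. Where it says the series, first, only, none or still open, it means among the compounds named here.

Values in a functional assay on HL-60 cells (Homo sapiens) for antiproliferative activity, read by MTT assay, with a stated time of 72 h (on this read-out higher numbers stand for weaker inhibition and lower numbers for stronger inhibition), are as follows:

- Compound 1 `COc1cc(-c2ncnn2-c2cccc(N)c2)cc(OC)c1OC` gives > 10000 nM as a limit
- Compound 2 `COc1cccc(-c2ncnn2-c2cc(OC)c(OC)c(OC)c2)c1` gives > 10000 nM as a limit
- Compound 3 `COc1cc(-n2ncnc2-c2ccc(OC(F)(F)F)cc2)cc(OC)c1OC` gives > 10000 nM as a limit

Compound 3 gives > 10000 nM as a limit of the assay and not a number. Among the compounds with values here, it stands with the other two compounds at the limit of > 10000 nM in this assay, at which 3 of the 3 values shown sit, and so the set holds no measured step by which a change could be sized.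

The next compound to be tested is compound 4 `COc1cc(-n2ncnc2-c2ccccc2)cc(OC)c1OC` which has hydrogen in place of trifluoromethoxy on an aromatic carbon, para to a large group. The count for this change is hydrogen in place of trifluoromethoxy on an aromatic carbon in full.

No step beyond the scatter is expected in this assay in either direction, since compound 3 and its two companions all sit at the limit of > 10000 nM in this assay, at which 3 of the 3 values shown sit, without a number among them. The estimated outcome is a number no higher from compound 3 to compound 4 (the limit leaves the size open) and it should be read as an expectation only. Compound 4 is expected at 10000 nM with an estimated range from 3000 nM to 30000 nM and a good chance of a limit instead of a number.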

Compound 4, half-maximal inhibitory concentration: > 10000 nM
Compound 4 was reported as a limit; the forecaster's own chance of this, stated with the estimate: 75%; the middle value lies on the limit itself.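

No step to compound 4 can be read from compound 2 or compound 3 in this assay, since all of these compounds sit at a limit of the assay and not at a number: the limit of > 10000 nM in this assay, at which 4 of the 4 values shown sit.

The compounds shown leave open how far either change shifts the value, and whether any compound of this series gives a measured number.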